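Thiobenzamide amides: saturated versus unsaturated branched chain

The compounds below may be only part of what the source reports. "The series", "measured", "known", "first", "only" and "open" are said of these compounds alone.

Compound 1 `COc1cc(CNC(=O)CCCCCCC(C)C)ccc1OC(=O)c1ccc(C(N)=S)cc1`, compound 2 `COc1cc(CNC(=O)CCCC/C=C/C(C)C)ccc1OC(=O)c1ccc(C(N)=S)cc1` and compound 3 `COc1cc(CNC(=O)CCCC/C=C/C(C)C)ccc1OCCCCCOc1ccc(C(N)=S)cc1` have been measured in a functional assay on HeLa cells (Homo sapiens) for antiproliferative activity, read by MTT assay, with a stated time of 48 h; on this read-out lower numbers stand for stronger inhibition and higher numbers for weaker inhibition. Compound 1 reaches only the limit of this assay, reported as > 50000 nM. Compound 2 gives 39600 nM in this assay, and compound 3 gives 46400 nM. The change from compound 2 to compound 1 is isopentyl in place of 3-methylbut-1-en-1-yl on a saturated chain carbon, four bonds along the chain from a carbonyl carbon and gives an at least 1.2-fold higher number from compound 2 to compound 1 (0.10 log units; that floor lies within the scatter); the floor of that step is set by the limit of > 50000 nM in this assay, at which 1 of the 3 values shown sits, so its true size is not known. How the cores of compound 2 and compound 3 differ is not broken down here; their two values in this assay lie within the usual scatter of each other, so no order between them is claimed.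

Compound 4 `COc1cc(CNC(=O)CCCCCCC(C)C)ccc1OCCCCCOc1ccc(C(N)=S)cc1` is not yet measured. It differs from compound 3 by isopentyl in place of 3-methylbut-1-en-1-yl on a saturated chain carbon, four bonds along the chain from a carbonyl carbon, which is the same change as that from compound 2 to compound 1, made at the same place on the chain. The step from compound 3 to compound 4 in this assay is expected to be about a 1.3-fold higher number from compound 3 to compound 4 (0.11 log units; within the scatter), resting on the earlier step from compound 2 to compound 1 and on the value of compound 3, 46400 nM. Compound 4 is therefore estimated at 60000 nM, with a range from 35000 nM to 120000 nM, and it is expected that this assay may report only a limit for it rather than a number.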

Compound 4, half-maximal inhibitory concentration: > 50000 nM
Compound 4 ended at the assay's limit; the forecaster's own chance of this, stated with the estimate: 65%; the middle value is on the limit's open side.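

On the core of compound 3, isopentyl in place of 3-methylbut-1-en-1-yl, on a saturated chain carbon, four bonds along the chain from a carbonyl carbon, gives in this assay an at least 1.0-fold higher number from compound 3 to compound 4 (0.03 log units; that floor lies within the scatter). Compound 4 gives > 50000 nM, which is a limit of the assay and not a number, so the step has only a floor and no measured size: the limit of > 50000 nM in this assay, at which 2 of the 4 values shown sit. The series shows that the isopentyl compound on each of the two cores ends at this limit, but it does not show that a step of a given size carries from one core to the other, that the two steps are equal, or that either step goes beyond the usual scatter: the same change on two cores in this assay, an at least 1.2-fold higher number (0.10 log units; that floor lies within the scatter) from compound 2 to compound 1 and an at least 1.0-fold higher number (0.03 log units; that floor lies within the scatter) from compound 3 to compound 4; the limit leaves it open whether they differ.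

The compounds shown leave open how a longer chain, or an amine or a carboxylic acid in place of isopentyl, would read in this assay, and whether any such group on either core gives a value clear of the limit. They also leave open whether an amide or a nitrile in place of the thioamide would change the picture on these cores.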